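The source may report more compounds than this note shows. Statements on the series, on what has been measured and on what is new or still open speak of the compounds shown alone.

Working notes on the series, all read in a functional assay on cells (+SA cell, Mus musculus) for cytotoxicity, read by MTT assay, with a stated time of 24 h; on this read-out lower numbers stand for stronger inhibition and higher numbers for weaker inhibition. Compound 1 `CC(C)=CCC/C(C)=C/CC/C(C)=C/CC[C@]1(C)CCc2cc(OC(=O)c3cc(C(=O)O)ccc3C(=O)O)c(C)c(C)c2O1` gives 1440 nM and compound 2 `CC(C)=CCC/C(C)=C/CC/C(C)=C/CC[C@]1(C)CCc2cc(OC(=O)/C=C\C(=O)O)c(C)c(C)c2O1` gives 2300 nM, and a 1.6-fold higher number from compound 1 to compound 2 (0.20 log units; within the scatter). Compound 3 `CC(C)=CCC/C(C)=C/CC/C(C)=C/CC[C@]1(C)CCc2cc(OC(=O)CC(C)CC(=O)O)c(C)c(C)c2O1` gives 19200 nM, the highest number of the three and so the weakest inhibitor measured so far.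

Compound 4 `CC(C)=CCC/C(C)=C/CC/C(C)=C/CC[C@]1(C)CCc2cc(OC(=O)c3ccccc3)c(C)c(C)c2O1` departs from compound 3 by phenyl in place of 2-(carboxymethyl)propyl on a carbonyl carbon.

Among the measured compounds shown here, two measured steps bear on this change, a 13-fold higher number from compound 1 to compound 3 (1.12 log units; beyond the scatter) and an 8.3-fold higher number from compound 2 to compound 3 (0.92 log units; beyond the scatter). Both replace a different group at the same place, and both end at the highest number. For the measured compounds named here, neither is a direct match, since no measured compound carries a plain phenyl. The closest group is the 2,5-dicarboxyphenyl of compound 1 at 1440 nM, so a ring on the carbonyl carbon points to a lower number than compound 3 shows. On these data alone, how much of that step survives without the two carboxy groups is unknown, so only part of it is expected here.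

The expected change is a 3.2-fold lower number from compound 3 to compound 4 (0.51 log units; beyond the scatter), towards stronger inhibition. For compound 4 the estimated value is 6000 nM, with an expected range from 1500 nM to 25000 nM.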

Compound 4, half-maximal inhibitory concentration: 6550 nM
Beside the measured number, compound 4's estimate is 1.1-fold (0.04 log units) below it; the measured number falls inside the stated range.
By their numbers in this assay, from the lowest: compounds 1 and 2 (each within the scatter of the next); then compound 4; then compound 3.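

Even with no carboxy group and no hydrogen-bond donor on the group at the carbonyl carbon, the plain phenyl of compound 4 improves on the 2-(carboxymethyl)propyl of compound 3, with a 2.9-fold lower number from compound 3 to compound 4 (0.47 log units; beyond the scatter), so a free carboxy group is not needed for a number lower than that of compound 3. The carboxy-bearing groups of the other two compounds still do better than phenyl, with a 4.5-fold higher number from compound 1 to compound 4 (0.66 log units; beyond the scatter) and a 2.8-fold higher number from compound 2 to compound 4 (0.45 log units; beyond the scatter), and the first of these steps shows that stripping both carboxy groups from the ring costs more than the scatter, although compound 3 goes against any simple link between a carboxy group and a lower number, as it carries one and gives the highest number of the four. Nothing measured on these compounds gives a reason for this order at the position.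

The compounds shown leave open whether one carboxylic acid on the phenyl ring would be enough to reach the numbers of compound 1, or which of its two carboxy groups carries the step. They also leave open how an amine on that ring, or a longer chain in place of the 2-(carboxymethyl)propyl, would read on this position.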